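A few compounds are considered here, and "the series" means these few. Any claim that something is new, unique, unknown or untested is made for them only; others in the source may bear on it.

Working notes on the series. Going by the values given here, in an ADME assay on HaCaT cells (Homo sapiens) for cytotoxicity, read by MTT assay, with a stated time of 48 h (on this read-out higher numbers stand for an effect only at larger amounts of compound and lower numbers for an effect already at smaller amounts), compound 1 `CCOC(=O)[C@@H](N)CCC(=O)NCCSC(=O)c1ccccc1` gives 331000 nM, the higher of the two numbers so far, and compound 2 `CCCCOC(=O)[C@@H](N)CCC(=O)NCCSC(=O)c1ccccc1` gives 97000 nM. Compound 3 `CCOC(=O)[C@@H](N)CCC(=O)NCCSC(=O)C(C)(C)C` differs from compound 1 by a single change on a carbonyl carbon: tert-butyl in place of phenyl on a carbonyl carbon. Among the compounds with values here, no measured step touches that place. Within the data shown here, the only step available, a 3.4-fold lower number from compound 1 to compound 2 (0.53 log units; beyond the scatter), is modest and lies beyond the scatter, but it sits elsewhere in the structure. It therefore offers a scale for one change in the series and no direction for this one. In this assay, a step no larger than that one is expected, most likely within the scatter and with only a weak lean toward a lower number. For compound 3 the estimated value is 250000 nM, with an expected range of 100000 nM to 600000 nM. This estimate means an expected 1.3-fold lower number from compound 1 to compound 3 (0.12 log units; within the scatter).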

Compound 3, half-maximal effective concentration: 228000 nM
For compound 3 the middle estimate is 1.1-fold (0.04 log units) above the measured one, within the range that was stated.
By their numbers in this assay, from the lowest: compound 2; then compounds 3 and 1 (each within the scatter of the next).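

At this place, on a carbonyl carbon whose other neighbours are sulfur, the exchange of phenyl for tert-butyl gives a 1.5-fold lower number from compound 1 to compound 3 (0.16 log units; within the scatter) in this assay. The one six-membered aromatic ring of carbon only can therefore leave, with 6 heavy atoms replaced by 4, without a change in the read-out beyond the scatter, unlike the chain change in a 3.4-fold lower number from compound 1 to compound 2 (0.53 log units; beyond the scatter). No available data explain this result.

The compounds shown leave open how a longer chain, an amine or a carboxylic acid on this carbonyl carbon would read in this assay. They also leave open whether the ethyl in place of hydrogen on the saturated chain carbon that separates compound 2 from compound 1 would shift the number in the same way when added to compound 3.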